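Swapping the trimethoxyphenyl of compound 1 for chlorophenyl

A few compounds are considered here, and "the series" means these few. Any claim that something is new, unique, unknown or untested is made for them only; others in the source may bear on it.

Compound 1 `COc1cc(-c2nc(CO[C@@H]3O[C@H](CSc4ncn[nH]4)[C@H]4OC5(CCCC5)O[C@@H]34)no2)cc(OC)c1OC`: 28000 nM
Compound 2 `COc1cc(-c2nc(CO[C@@H]3O[C@H](CSc4nnc(N)s4)[C@H]4OC5(CCCC5)O[C@@H]34)no2)cc(OC)c1OC`: 36000 nM

Both compounds were tested in a functional assay on A549 cells (Homo sapiens) for antiproliferative activity, read by sulforhodamine B assay, with a stated time of 48 h; on this read-out lower numbers stand for stronger inhibition of growth and higher numbers for weaker inhibition of growth. Among the compounds with values here, compound 1 stands at the lowest of the two numbers, yet the only neighbouring step, a 1.3-fold higher number from compound 1 to compound 2 (0.11 log units; within the scatter), does not separate the two compounds in a meaningful way. That step concerns the group on the sulfur, not the aromatic ring at the far end of the shared core.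

Compound 3 `Clc1ccc(-c2nc(CO[C@@H]3O[C@H](CSc4ncn[nH]4)[C@H]4OC5(CCCC5)O[C@@H]34)no2)cc1` changes exactly that far end: 4-chlorophenyl in place of 3,4,5-trimethoxyphenyl on an aromatic carbon. Within the data shown here, no measured step touches this position, so nothing in the data points to a direction for this change, and the single step that exists is itself within the scatter. The estimate for compound 3 therefore rests on compound 1 alone, with a wide range. Compound 3 is expected to give 35000 nM, with a range from 10000 nM to 120000 nM. This estimate means an expected step of a 1.3-fold higher number from compound 1 to compound 3 (0.10 log units; within the scatter), which is not judged to exceed the scatter.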

Compound 3, concentration for 50% growth inhibition: 13000 nM
Compound 3: middle estimate off by 2.7-fold (0.43 log units), on the high side; the range from low to high includes it.
By their numbers in this assay, from the lowest: compound 3; then compounds 1 and 2 (each within the scatter of the next).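

Within the data shown here, this is the first measured step at the far end of the shared core, and in this assay it clears the scatter, with a 2.2-fold lower number from compound 1 to compound 3 (0.33 log units; beyond the scatter) as a modest change. The earlier step on the sulfur, a 1.3-fold higher number from compound 1 to compound 2 (0.11 log units; within the scatter), did not separate its two compounds, so this aromatic ring is the first place shown where a change moves the number beyond the scatter. The swap exchanges a group of 12 heavy atoms with 3 hydrogen-bond acceptors for one of 7 heavy atoms with 0 acceptors, and nothing measured here explains the shift.

Because the methoxy groups leave and a chlorine enters in one step, the compounds shown cannot say which of the two matters; plain phenyl and 4-methoxyphenyl at this position would help to separate them. From the compounds shown here alone, whether 4-chlorophenyl gives a similar step with 5-amino-1,3,4-thiadiazol-2-yl on the sulfur also stays open.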